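Tail variation on the pyridine ether of a urea series

The source may hold more compounds than are shown below. What is called first, only, known or untested is meant among the compounds shown, and "the series" means these compounds.

Measured compounds:
compound 1 `CC(C)COc1nc(C(F)(F)F)ccc1CNC(=O)Nc1cccc2c(=O)[nH]ccc12`: 78.7 nM
compound 2 `O=C(NCc1ccc(C(F)(F)F)nc1OCc1ccccc1)Nc1cccc2c(=O)[nH]ccc12`: 78.6 nM

In an assay on CHO cells for agonist activity at transient receptor potential cation channel subfamily V member 1 (Homo sapiens) (a lower number here means that less compound is needed, a higher number that more compound is needed for the effect), compound 2 gives 78.6 nM, and compound 1 gives 78.7 nM; the two values lie within the usual scatter of each other, so neither stands apart. Compound 3 `O=C(NCc1ccc(C(F)(F)F)nc1SC1CCCCC1)Nc1cccc2c(=O)[nH]ccc12` carries cyclohexylsulfanyl in place of benzyloxy on an aromatic carbon. For the measured compounds named here, the only measured step, a 1.0-fold lower number from compound 1 to compound 2 (0.00 log units; within the scatter), changed the chain on the oxygen-linked carbon and left the number flat; no measured pair exchanges the oxygen link itself or trades an aromatic ring for a saturated one. Going by the values given here, with only that flat step to lean on, compound 3 is expected to land near compound 2, with a 1.3-fold higher number from compound 2 to compound 3 (0.10 log units; within the scatter), estimated at 100 nM within 30 nM to 400 nM.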

Compound 3, half-maximal effective concentration: 69.3 nM
Compound 3: middle estimate off by 1.4-fold (0.16 log units), on the high side; the range from low to high includes it.
By their numbers in this assay, from the lowest: compounds 3, 2 and 1 (each within the scatter of the next).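

Moving from an oxygen link to a sulfur link and from an aromatic to a non-aromatic ring at this aromatic carbon, next to the ring nitrogen, gives a 1.1-fold lower number from compound 2 to compound 3 (0.05 log units; within the scatter) in this assay and a 1.1-fold lower number from compound 1 to compound 3 (0.06 log units; within the scatter) on the same read-out. The earlier pair varied only the chain on the oxygen, whereas these steps show that the number also stays flat across a change of link atom and ring type. Nothing available explains this flatness. Going by these compounds, an amine or a carboxylic acid at this carbon remains open, as does a methoxy tail. The shared core and its urea remain unexplored in the compounds shown.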